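Cyclopropylamino in place of cyclopentylamino on a shared core

The source may hold more compounds than are shown below. What is called first, only, known or untested is meant among the compounds shown, and "the series" means these compounds.

Compound 1, `Fc1ccc(-c2nn3c(NC4CC4)cc(Cl)cc3c2-c2ccnc(NC3CCCC3)n2)cc1`: in an ADME assay on Vero cells (Chlorocebus sabaeus) for cytotoxicity (on this read-out lower numbers stand for higher toxicity in this test and higher numbers for lower toxicity in this test), compound 1 gives > 40000 nM, which is a limit of the assay and not a number.
Compound 2, `COc1ccc(-c2nn3c(Cl)cc(Cl)cc3c2-c2ccnc(NC3CCCC3)n2)cc1`: in this assay compound 2 gives > 40000 nM, again a limit.
Compound 3, `COc1ccc(-c2nn3c(NC4CCCC4)cc(Cl)cc3c2-c2ccnc(NC3CCCC3)n2)cc1`: in this assay compound 3 gives > 40000 nM, also a limit.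

All three measured compounds therefore sit at the same point, (the limit of > 40000 nM in this assay, at which 3 of the 3 values shown sit), and none of them yields a number. For the measured compounds named here, the one measured step that changes a single place, a step that the two limits leave unreadable from compound 2 to compound 3, puts cyclopentylamino in place of chloro on an aromatic carbon, but with both ends at the limit its size cannot be read.

Compound 4, `COc1ccc(-c2nn3c(NC4CC4)cc(Cl)cc3c2-c2ccnc(NC3CCCC3)n2)cc1`, is not yet measured. It differs from compound 3 by cyclopropyl in place of cyclopentyl on a nitrogen on an aromatic ring. Going by the values given here, no measured step bears directly on swapping one cycloalkyl group for another on this nitrogen; the only comparison available, from compound 2 to compound 3, is itself unreadable. What the three compounds show is simply that compound 1, compound 2 and compound 3 all remain at the limit in this assay.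

On that basis compound 4 is expected to behave like its neighbours, with an estimated step that the limit leaves unreadable from compound 3 to compound 4 that is none beyond the scatter. The estimate for compound 4 in this assay is 60000 nM, with a range from 30000 nM to 200000 nM, most likely reported again only as a limit.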

Compound 4, half-maximal cytotoxic concentration: > 40000 nM
Compound 4 was reported as a limit; the forecaster's own chance of this, stated with the estimate: 85%; the middle value lies beyond the limit too.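

In this assay compound 4 gives > 40000 nM, again a limit and not a number. Its steps from compound 1, compound 2 and compound 3 therefore cannot be read: the limit of > 40000 nM in this assay, at which 4 of the 4 values shown sit.

The compounds shown leave open whether any of these changes on the shared core alters the read-out at all, and how far beyond the limit each compound lies.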